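Piperazine arm swap in a growth-inhibition series

This account rests on a few compounds, and the source may have more. Where it says the series, first, only, none or still open, it means among the compounds named here.

Three compounds of this series have numbers in a functional assay on SW-620 cells (Homo sapiens) for inhibition, read by MTT assay, with a stated time of 72 h; on this read-out higher numbers stand for weaker inhibition of growth and lower numbers for stronger inhibition of growth. Compound 1 `Cc1cc(CN2CCN(c3c(Cl)cnc4[nH]c(-c5ccoc5)nc34)CC2)no1` gives 6500 nM. Compound 2 `Cc1nn(C)cc1-c1nc2c(N3CCN(Cc4ncn(C)n4)CC3)c(Cl)cnc2[nH]1` gives 3140 nM, the lowest of the three; compound 1 stands nearest to it and compound 3 furthest, both gaps beyond the scatter. Compound 3 `Cc1cc(CN2CCN(c3c(Br)cnc4[nH]c(-c5csnn5)nc34)CC2)no1` gives 20000 nM. For the measured compounds named here, these three differ from one another in several places at once, so no single step between measured compounds can be read off from them.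

Compound 4 `Cc1nn(C)cc1-c1nc2c(N3CCN(Cc4cnccn4)CC3)c(Cl)cnc2[nH]1` is not yet measured. It differs from compound 2 in one place: pyrazin-2-yl in place of 1-methyl-1H-1,2,4-triazol-3-yl on a saturated chain carbon bound to an amine nitrogen in a ring. Cut one bond further out, the same difference reads (1-methyl-1H-1,2,4-triazol-3-yl)methyl to (pyrazin-2-yl)methyl. Going by the values given here, no measured pair shows the effect of this change, or of any other change on the saturated chain carbon bound to an amine nitrogen in a ring, so its direction is open. The expected step is a 1.1-fold higher number from compound 2 to compound 4 (0.05 log units; within the scatter), small enough to sit within the usual scatter. Compound 4 is estimated at 3500 nM, within 1200 nM to 10000 nM.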

Compound 4, concentration for 50% growth inhibition: 1090 nM
Compound 4: the middle estimate sits 3.2-fold (0.51 log units) above what was measured, and the stated range ends above it.
By their numbers in this assay, from the lowest: compound 4; then compound 2; then compound 1; then compound 3.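

In this assay, for the compounds shown here, the step from pyrazin-2-yl in place of 1-methyl-1H-1,2,4-triazol-3-yl is a 2.9-fold lower number from compound 2 to compound 4 (0.46 log units; beyond the scatter), the first single-place reading, and it shows that the group on a saturated chain carbon bound to an amine nitrogen in a ring can move the number beyond the scatter. Both groups hold 6 heavy atoms, so this modest step arises with no change in that count, between a five-membered and a six-membered aromatic ring. Nothing measured here accounts for the step.

On these data alone, this position rests on a single pair, so whether the step carries over to the cores of compound 1 or compound 3 remains open. Also open, as far as these compounds go, is how a phenyl ring or an open-chain amine would read on the same carbon.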